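A few compounds are considered here, and "the series" means these few. Any claim that something is new, unique, unknown or untested is made for them only; others in the source may bear on it.

Measured in a functional assay on NALM-6 cells (Homo sapiens) for cytotoxicity, read by MTT assay, with a stated time of 46 h; a lower number here means a stronger inhibitor, a higher number a weaker inhibitor:
compound 1 `O=C1/C(=C\c2ccccc2)C(c2ccccc2)Oc2ccccc21`: > 1000000 nM
compound 2 `Cc1ccc(/C=C2\C(=O)c3ccccc3OC2c2ccccc2)cc1`: > 1000000 nM
compound 3 `Cc1ccc(/C=C2/C(=O)c3ccccc3OC2c2ccccc2)cc1`: 51400 nM

Within the data shown here, compound 3 holds the only number in this set, and the other two entries are limits (the limit of > 1000000 nM in this assay, at which 2 of the 3 values shown sit). The next compound, compound 4 `O=C1/C(=C/c2ccc(Br)cc2)C(c2ccccc2)Oc2ccccc21`, keeps the double bond as drawn in compound 3 and differs at one place: bromo in place of methyl on an aromatic carbon, that is, 4-methylphenyl to 4-bromophenyl.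

Among the measured compounds shown here, two measured steps bear on this. The step that the two limits leave unreadable from compound 1 to compound 2 touches the same place but gives no readable size. The step of an at least 19-fold lower number from compound 2 to compound 3 (1.28 log units; beyond the scatter) is large, but it concerns the double bond, which does not change here, and it comes with a caveat: the fact that one of compounds 2 and 3 is drawn with a defined configuration and the other without, at the place where they differ.

For the measured compounds named here, no measured step therefore shows what bromo in place of methyl does. The working expectation in this assay is no step beyond the scatter, in neither direction, anchored on compound 3 at 51400 nM. The expected step is a 1.4-fold lower number from compound 3 to compound 4 (0.13 log units; within the scatter). The estimate for compound 4 is 38000 nM, with an expected range of 10000 nM to 150000 nM.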

Compound 4, half-maximal inhibitory concentration: 6900 nM
For compound 4 the middle estimate is 5.5-fold (0.74 log units) above the measured one; measured number below the stated range.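

In this assay the place on the aromatic carbon now has a readable size: 4-methylphenyl to 4-bromophenyl gives a 7.4-fold lower number from compound 3 to compound 4 (0.87 log units; beyond the scatter) with the double bond kept as drawn in compound 3. The earlier step at this place, between compound 1 and compound 2, cannot be read, as both entries are limits, so this is the only measured size for a change here. Nothing in hand gives a measured property that accounts for this step.

Open, from the compounds shown here alone, is whether the lower number is particular to bromo or also appears with other groups at this place, such as chloro, methoxy or an amine. Also open, going by these compounds, is what hydrogen at this place gives with the double bond as drawn in compound 3 and compound 4.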